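The compounds below may be only part of what the source reports. "The series", "measured", "known", "first", "only" and "open" are said of these compounds alone.

Compound 3 `CC(C(=O)NCc1ccc(C(C)(C)C)cc1)c1ccc(NS(C)(=O)=O)c(C#N)c1` gives the highest number of the three measured compounds in a functional assay on CHO cells for antagonist activity at transient receptor potential cation channel subfamily V member 1 (Rattus norvegicus), read by fluorescence, with a stated time of 1 h (on this read-out higher numbers stand for weaker inhibition and lower numbers for stronger inhibition), at 467 nM. Compound 1 `CC(C(=O)NCc1ccc(C(C)(C)C)cc1)c1ccc(NS(C)(=O)=O)c(Cl)c1` gives 29.5 nM, and compound 2 `CC(C(=O)NCc1ccc(C(C)(C)C)cc1)c1ccc(NS(C)(=O)=O)c(I)c1` gives 30 nM. Compound 4 `Cc1cc(C(C)C(=O)NCc2ccc(C(C)(C)C)cc2)ccc1NS(C)(=O)=O` differs from compound 3 by methyl in place of cyano on an aromatic carbon. The measured steps that bear on this change run the other way, from chloro or iodo to cyano: a 16-fold higher number from compound 1 to compound 3 (1.20 log units; beyond the scatter) and a 16-fold higher number from compound 2 to compound 3 (1.19 log units; beyond the scatter), both large. Replacing the cyano with methyl is therefore expected to bring the number back down by a comparable amount, toward stronger inhibition in this assay, a 10-fold lower number from compound 3 to compound 4 (1.02 log units; beyond the scatter). Compound 4 is thus estimated at 45 nM, with a range from 15 nM to 140 nM.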

Compound 4, inhibition constant: 18.9 nM
Estimate against measurement, compound 4: 2.4-fold (0.38 log units) above; low and high end bracket the measured number.
By their numbers in this assay, from the lowest: compounds 4, 1 and 2 (each within the scatter of the next); then compound 3.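

Compound 3 now stands apart from both sides of the comparison: methyl brings the number down, with a 25-fold lower number from compound 3 to compound 4 (1.39 log units; beyond the scatter), yet methyl cannot be told from the halogens, with a 1.6-fold lower number from compound 2 to compound 4 (0.20 log units; within the scatter) and a 1.6-fold lower number from compound 1 to compound 4 (0.19 log units; within the scatter). At this position, ortho to a methanesulfonamido group, methyl, chloro and iodo thus sit together, and among the four groups shown only cyano carries a large loss of inhibition. Nothing measured here accounts for the cyano result. Still open, as far as these compounds go, is how plain hydrogen, a methoxy group, an amine or a longer chain such as ethyl would fare at this position.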